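Working notes: from compound 2 to compound 3

A few compounds are considered here, and "the series" means these few. Any claim that something is new, unique, unknown or untested is made for them only; others in the source may bear on it.

Measured in an ADME assay on J774.A1 cells (Mus musculus) for cytotoxicity, read by MTT assay, with a stated time of 48 h; on this read-out lower numbers stand for higher toxicity in this test and higher numbers for lower toxicity in this test
- compound 1 `COc1ccc(CNC(=O)c2c([N+](=O)[O-])noc2-c2ccc(Cl)cc2Cl)cc1` gives 80500 nM
- compound 2 `O=C(NCc1cccc(Br)c1)c1c([N+](=O)[O-])noc1-c1ccc(Cl)cc1Cl` gives 71200 nM

For the measured compounds named here, compound 2 has only one neighbour on these numbers, and the two cannot be told apart: a 1.1-fold lower number from compound 1 to compound 2 (0.05 log units; within the scatter). Next in line is compound 3 `O=C(NCc1cccc(Cl)c1Cl)c1c([N+](=O)[O-])noc1-c1ccc(Cl)cc1Cl`, still without a measurement in this assay. The structural change is 2,3-dichlorophenyl in place of 3-bromophenyl on a saturated chain carbon bound to an amide-type nitrogen. Going by the values given here, only one measured step bears on this place, and it stayed within the scatter: a 1.1-fold lower number from compound 1 to compound 2 (0.05 log units; within the scatter). Among the compounds with values here, a single step is thin evidence, and no measured compound yet carries the 2,3-dichlorophenyl group. On that basis, no change beyond the scatter is expected, and the expected step is a 1.2-fold lower number from compound 2 to compound 3 (0.07 log units; within the scatter). For compound 3 the estimated value is 60000 nM, with an expected range from 29000 nM to 120000 nM.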

Compound 3, half-maximal cytotoxic concentration: 81800 nM
Beside the measured number, compound 3's estimate is 1.4-fold (0.13 log units) below it, and the stated range covers the measured number.
By their numbers in this assay, from the lowest: compounds 2, 1 and 3 (each within the scatter of the next).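

In this assay, replacing 3-bromophenyl with 2,3-dichlorophenyl on the saturated chain carbon bound to the amide-type nitrogen gives no change that can be told from the scatter (a 1.1-fold higher number from compound 2 to compound 3 (0.06 log units; within the scatter)). For the compounds shown here, the same holds against the 4-methoxyphenyl group of the first compound (a 1.0-fold higher number from compound 1 to compound 3 (0.01 log units; within the scatter)), so all three pairs among compound 1, compound 2 and compound 3 now lie within the scatter, and a group carrying two chlorine atoms behaves on this read-out like those carrying one bromine or one methoxy group. No measurement at hand offers a reason for this sameness.

As far as these compounds go, all three groups at this place are substituted phenyl rings on one saturated chain carbon, so it remains open whether the read-out would stay the same with an amine or a carboxylic acid on the ring, or with a longer chain in place of that single carbon. The shared core is also identical in compound 1, compound 2 and compound 3, which leaves the contribution of its own groups to these values unresolved.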